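Phenyl for Phenethyl: Expected Cytotoxicity of Compound 3

The source may hold more compounds than are shown below. What is called first, only, known or untested is meant among the compounds shown, and "the series" means these compounds.

Compound 1 `c1ccc(CCc2ccc3c(NCCCNCc4ccco4)ccnc3c2)cc1` was tested in an ADME assay on HepG2 cells (Homo sapiens) for cytotoxicity, read by luminescence, CellTiter-Glo and ATP content, with a stated time of 72 h (on this read-out higher numbers stand for an effect only at larger amounts of compound and lower numbers for an effect already at smaller amounts), where compound 1 gives 16000 nM. For the measured compounds named here, this is the higher of the two numbers measured so far. Its companion, compound 2 `COc1ccc(F)cc1CNCCCNc1ccnc2cc(Oc3ccc(C(C)(C)C)cc3)ccc12`, gives 7200 nM in this assay, a lower number, and the gap between the two lies beyond the usual scatter. The step of interest leads from compound 1 to compound 3 `c1ccc(-c2ccc3c(NCCCNCc4ccco4)ccnc3c2)cc1`, which has not yet been measured in this assay. The difference between the two structures is phenyl in place of phenethyl on an aromatic carbon. Going by the values given here, no measured pair in this set carries the same change, so the data give no direct guide to the size of the step. In this assay the expected step is a 1.1-fold higher number from compound 1 to compound 3 (0.05 log units; within the scatter), a move no larger than the usual scatter. On that basis the estimate for compound 3 in this assay is 18000 nM, within a range from 8000 nM to 40000 nM.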

Compound 3, half-maximal effective concentration: 5920 nM
The estimate for compound 3 lay 3.0-fold (0.48 log units) above the measured number, outside the stated range (below it).
By their numbers in this assay, from the lowest: compounds 3 and 2 (each within the scatter of the next); then compound 1.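

For the compounds shown here, putting phenyl in place of phenethyl on this aromatic carbon gives a 2.7-fold lower number from compound 1 to compound 3 (0.43 log units; beyond the scatter) in this assay, a step beyond the scatter that shows the number responds to the group at this position, something the earlier compounds could not show without a pair differing in one place. The lower number means that compound 3 has its effect at smaller amounts, although both groups carry the same six-membered aromatic ring of carbon only and the change removes only the two-carbon link present in phenethyl. Nothing available here offers an explanation for this step.

Going by these compounds, whether a benzyl group, a longer chain or an amine on this carbon would move the number further, and in which direction, remains open. Also open, on these data alone, is whether the same change would give a similar step with a different side chain on the shared core.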